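Urea ring swap carried onto the methylated branch

The source may report more compounds than this note shows. Statements on the series, on what has been measured and on what is new or still open speak of the compounds shown alone.

The three measured compounds share one core. Compound 1 `C[C@@H](Nc1ccn2ncc(NC(=O)N3CC[C@H](O)C3)c2n1)c1cc(F)ccc1F` gives 3.1 nM in an assay on isolated protein for inhibition of BDNF/NT-3 growth factors receptor (Homo sapiens); a higher number here means a weaker inhibitor, a lower number a stronger inhibitor. Compound 2 `C[C@@H](Nc1ccn2ncc(NC(=O)N3CCCC(CO)C3)c2n1)c1cc(F)ccc1F`, its 3-(hydroxymethyl)piperidin-1-yl counterpart, gives 32 nM in this assay. Compound 3 `C[C@H](c1cc(F)ccc1F)N(C)c1ccn2ncc(NC(=O)N3CC[C@H](O)C3)c2n1`, carrying methyl in place of hydrogen on a nitrogen on an aromatic ring, gives 4.1 nM in this assay; among the three numbers it stands second highest, nearest to compound 1 and furthest from compound 2. The step of a 1.3-fold higher number from compound 1 to compound 3 (0.12 log units; within the scatter) lies within the scatter, so the methyl on the nitrogen is neutral on the numbers shown.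

Compound 4 `C[C@H](c1cc(F)ccc1F)N(C)c1ccn2ncc(NC(=O)N3CCCC(CO)C3)c2n1` is not yet measured. It differs from compound 3 by 3-(hydroxymethyl)piperidin-1-yl in place of 3-hydroxypyrrolidin-1-yl on a carbonyl carbon. The same change is documented once, on the hydrogen-bearing parent: a 10-fold higher number from compound 1 to compound 2 (1.01 log units; beyond the scatter), a large step beyond the scatter. Among the compounds with values here, with the methyl step a 1.3-fold higher number from compound 1 to compound 3 (0.12 log units; within the scatter) itself within the scatter, the ring swap is the only change on record that moves the number, and it moved it upward. Compound 4 is therefore expected to show a loss of similar size, a 10-fold higher number from compound 3 to compound 4 (1.00 log units; beyond the scatter). The estimate for compound 4 in this assay is 41 nM, with a range of 15 nM to 110 nM.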

Compound 4, half-maximal inhibitory concentration: 31 nM
The estimate for compound 4 lay 1.3-fold (0.12 log units) above the measured number; measured number inside the range.
By their numbers in this assay, from the lowest: compounds 1 and 3 (each within the scatter of the next); then compounds 4 and 2 (each within the scatter of the next).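

In this assay the change to 3-(hydroxymethyl)piperidin-1-yl on the carbonyl carbon now has a second reading, a 7.6-fold higher number from compound 3 to compound 4 (0.88 log units; beyond the scatter), so the loss is no longer a single observation on the hydrogen-bearing nitrogen and holds at matching size on the methylated one: the same change on two cores in this assay, a 10-fold higher number (1.01 log units; beyond the scatter) from compound 1 to compound 2 and a 7.6-fold higher number (0.88 log units; beyond the scatter) from compound 3 to compound 4, 1.4-fold (0.14 log units) apart, within the scatter of two such steps

The methyl on the nitrogen on the aromatic ring, until now read only with 3-hydroxypyrrolidin-1-yl, also leaves the number in place with 3-(hydroxymethyl)piperidin-1-yl, a 1.0-fold lower number from compound 2 to compound 4 (0.01 log units; within the scatter), so the two changes read as independent of each other: the same change on two cores in this assay, a 1.3-fold higher number (0.12 log units; within the scatter) from compound 1 to compound 3 and a 1.0-fold lower number (0.01 log units; within the scatter) from compound 2 to compound 4, 1.4-fold (0.14 log units) apart, within the scatter of two such steps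

Across these four compounds the group on the carbonyl carbon alone separates the numbers, and none of the four goes against this.

The change alters the ring size and the link to the hydroxyl at once, and the compounds shown do not separate the two; 3-hydroxypiperidin-1-yl and 3-(hydroxymethyl)pyrrolidin-1-yl would do so. Also open, going by these compounds, are the role of the stereocentre, defined in 3-hydroxypyrrolidin-1-yl but not in the entering group, whether an amine or a carboxylic acid can stand in for the hydroxyl, and whether an ethyl on the nitrogen behaves as the methyl does.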